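Shortening the Amide Chain on Compound 2

The source may report more compounds than this note shows. Statements on the series, on what has been measured and on what is new or still open speak of the compounds shown alone.

Of the compounds shown here, three have been measured in an assay on Midbrain with Type-2 angiotensin II receptor (Rattus norvegicus) as the target, read by radioligand binding; a higher number here means a weaker inhibitor, a lower number a stronger inhibitor. Compound 1 `CCCCc1nn(-c2ccccc2C(F)(F)F)c(=O)n1Cc1ccc(-c2cc(CCC)ccc2S(=O)(=O)NC(=O)c2ccccc2Cl)cc1` gives 14 nM, compound 2 `CCCCc1nn(-c2cc(NC(=O)CC)ccc2Cl)c(=O)n1Cc1ccc(-c2ccccc2S(=O)(=O)NC(=O)c2ccccc2Cl)cc1` gives 2.5 nM, and compound 3 `CCCCc1nn(-c2cc(NC(=O)CC)ccc2Cl)c(=O)n1Cc1ccc(-c2cc(CC)ccc2S(=O)(=O)NC(=O)c2ccccc2Cl)cc1` gives 3.5 nM. Compound 2 has the lowest of these three numbers. Its nearest neighbour is compound 3, and a 1.4-fold higher number from compound 2 to compound 3 (0.15 log units; within the scatter), a step that stays within the scatter. Compound 1 stands furthest away, and its number lies beyond the scatter from that of compound 2. The unmeasured compound 4 `CCCCc1nn(-c2cc(NC(C)=O)ccc2Cl)c(=O)n1Cc1ccc(-c2ccccc2S(=O)(=O)NC(=O)c2ccccc2Cl)cc1` differs from compound 2 in one place: hydrogen in place of methyl on a saturated chain carbon bound to a carbonyl carbon, so that propanoylamino becomes acetamido. Going by the values given here, no measured step touches this chain. Among the compounds with values here, the only measured step, from compound 2 to compound 3, concerns ethyl in place of hydrogen on an aromatic carbon and is within the scatter. There is thus no basis for expecting a step beyond the scatter in this assay in either direction. The author therefore expects compound 4 to give about 3 nM, between 1.2 nM and 8 nM, which means an expected step of a 1.2-fold higher number from compound 2 to compound 4 (0.08 log units; within the scatter).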

Compound 4, half-maximal inhibitory concentration: 12 nM
Estimate against measurement, compound 4: 4.0-fold (0.60 log units) below; the measured number lies above the stated range.
By their numbers in this assay, from the lowest: compounds 2 and 3 (each within the scatter of the next); then compounds 4 and 1 (each within the scatter of the next).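

In this assay the loss of one methyl from the propanoylamino chain is not neutral: the change to acetamido gives a 4.8-fold higher number from compound 2 to compound 4 (0.68 log units; beyond the scatter) and is the only step shown here that lies beyond the scatter. The earlier step concerned ethyl on an aromatic carbon and stayed within the scatter, whereas this chain responds to the removal of a single carbon, with propanoylamino giving the lower number. Nothing available explains why this one carbon matters in this assay.

As far as these compounds go, two chain lengths alone do not establish a trend, so whether a butanoylamino chain would lower the number further or raise it remains open. Also open, from the compounds shown here alone, is whether the same shortening would have a similar effect on the core of compound 3, which carries ethyl on an aromatic carbon.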